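Dimethylamino to methyl swap, two places, topoisomerase 1 series

The source may hold more compounds than are shown below. What is called first, only, known or untested is meant among the compounds shown, and "the series" means these compounds.

Measured so far:
compound 1, `Cc1ccc2nc(-c3ccccc3N(C)C)[nH]c(=O)c2c1`, 82.9%
compound 2, `CN(C)c1ccc2nc(-c3cccc4ccccc34)[nH]c(=O)c2c1`, 100%
compound 3, `Cc1ccc2nc(-c3ccccc3C)[nH]c(=O)c2c1`, 0%

In an assay on isolated protein for inhibition of DNA topoisomerase 1 (Homo sapiens), with a stated time of 30 min, tested at 100 uM (a lower number here means a weaker effect, a higher number a stronger effect of the compound at the concentration tested), compound 2 stands highest of the three, with compound 1 nearest and compound 3 furthest; both gaps are beyond the scatter. How compound 2 differs from compound 1 is not broken down here, since the two cores differ in more than one place.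

Among the measured compounds shown here, the one step that is counted runs from compound 1 to compound 3: methyl in place of dimethylamino on an aromatic carbon It gives a number 82.9 percentage points lower from compound 1 to compound 3 (beyond the scatter) in this assay, so a single exchange of this kind is enough to remove all measurable effect in that pair.

Compound 4, `Cc1ccc2nc(-c3cccc4ccccc34)[nH]c(=O)c2c1`, is not yet measured. It arises from compound 2 by the same kind of change: methyl in place of dimethylamino on an aromatic carbon The place is not the same, however. In compound 1 the dimethylamino that leaves sits "ortho to a large group" on a six-membered carbon ring that is not fused; in compound 2 it sits on the fused two-ring system, "meta to a fused ring; para to a fused ring". Compound 3 and compound 1 both already carry a methyl on that fused system, and compound 1 still shows a strong effect there, so the large loss seen from compound 1 to compound 3 need not carry over.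

For compound 4 a step of a number 45 percentage points lower from compound 2 to compound 4 (beyond the scatter) in this assay is expected, resting on the large drop of a number 82.9 percentage points lower from compound 1 to compound 3 (beyond the scatter) set against the strong reading of compound 1 with a methyl on its core. Compound 4 is thus estimated at 55%, with a wide range from 10% to 95%.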

Compound 4, a percentage reported as inhibition, at one concentration (the size of the read-out at that concentration, not a potency): 4.1%
Compound 4: the middle estimate sits 50.9 percentage points above what was measured; measured number outside the range, below it.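

In this assay the exchange of dimethylamino for methyl on the fused two-ring system gives a number 95.9 percentage points lower from compound 2 to compound 4 (beyond the scatter), a large step that leaves little of the effect. Set beside the earlier step, made on a ring that is not fused, the exchange removes the effect to a similar extent in both pairs: the same change on two cores in this assay, a number 82.9 percentage points lower (beyond the scatter) from compound 1 to compound 3 and a number 95.9 percentage points lower (beyond the scatter) from compound 2 to compound 4, 13 percentage points apart, within the scatter of two such steps The two pairs thus agree even though the place of the exchange differs, with compound 3 at 0% and compound 4 at 4.1%, but two pairs make no rule for other cores, and a read-out at one concentration that ends close to zero in both gives no measure of the loss in potency and no reason for it.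

Going by these compounds, only dimethylamino and methyl appear at the exchanged places, so it remains open how an unsubstituted amine, a methylamino group, a methoxy group or a longer chain such as diethylamino would read in this assay. Also open, on these data alone, is how the series reads at concentrations other than the one tested, and whether a core carrying dimethylamino at both places goes beyond what a single such group gives.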